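This account rests on a few compounds, and the source may have more. Where it says the series, first, only, none or still open, it means among the compounds named here.

Among the compounds with values here, compound 3 `CN1CCN(CCn2c(N)c(-c3nc4ccccc4[nH]3)c3nc(C#N)c(C#N)nc32)CC1` is the one member of the set with a numerical reading: in a functional assay on HL60/MX2 cells (Homo sapiens) for antiproliferative activity, read by MTT assay, with a stated time of 48 h (on this read-out lower numbers stand for stronger inhibition and higher numbers for weaker inhibition), compound 3 gives 6490 nM. Compound 1 `Cn1c(N)c(-c2nc3ccccc3[nH]2)c2nc(C#N)c(C#N)nc21` reaches only the limit of this assay, at > 50000 nM. Compound 2 `N#Cc1nc2c(-c3nc4ccccc4[nH]3)c(N)n(CCN3CCCC3)c2nc1C#N` likewise stops at the limit, > 50000 nM. Both limits sit at the same point, (the limit of > 50000 nM in this assay, at which 2 of the 3 values shown sit), so the step that the two limits leave unreadable from compound 1 to compound 2 cannot be read, while the steps of an at least 7.7-fold lower number from compound 1 to compound 3 (0.88 log units; beyond the scatter) and an at least 7.7-fold lower number from compound 2 to compound 3 (0.88 log units; beyond the scatter) both lie beyond the scatter. Compound 4 `CCCCn1c(N)c(-c2nc3ccccc3[nH]2)c2nc(C#N)c(C#N)nc21` carries the change (ethyl in place of 4-methylpiperazin-1-yl on a saturated chain carbon, two bonds along the chain from an aromatic nitrogen). The step that bears most directly on it is an at least 7.7-fold lower number from compound 2 to compound 3 (0.88 log units; beyond the scatter), where exchanging pyrrolidin-1-yl for 4-methylpiperazin-1-yl brought the number down from the limit; removing 4-methylpiperazin-1-yl altogether, with ethyl entering and no ring and no hydrogen-bond acceptor in its place, points the other way, and an at least 7.7-fold lower number from compound 1 to compound 3 (0.88 log units; beyond the scatter) supports the same reading. A loss well beyond the scatter is therefore expected, a 6.2-fold higher number from compound 3 to compound 4 (0.79 log units; beyond the scatter). For compound 4 the estimated value is 40000 nM, with a range from 12000 nM to 150000 nM, and a real chance that only a limit is reported.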

Compound 4, half-maximal inhibitory concentration: > 50000 nM
Compound 4: a limit, no number (the forecaster's own chance of this, stated with the estimate: 60%); middle value at least 1.2-fold (0.09 log units) away from the limit.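

Exchanging the 4-methylpiperazin-1-yl end group for ethyl on the saturated chain carbon, which turns the side chain into butyl, gives an at least 7.7-fold higher number from compound 3 to compound 4 (0.88 log units; beyond the scatter), so a plain chain at this position does not keep the numerical reading. Within the data shown here, of the four compounds in this assay, only the one carrying 4-methylpiperazin-1-yl gives a number, while the methyl, the 2-(pyrrolidin-1-yl)ethyl and now the butyl compounds do not, so neither a chain of this length nor a ring-bearing amine on it is enough by itself. The steps among compounds 1, 2 and 4 cannot be read because all three values are limits, not numbers: the limit of > 50000 nM in this assay, at which 3 of the 4 values shown sit.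

From the compounds shown here alone, whether a piperidine or morpholine end group would give a numerical reading remains open. So does the effect of a longer chain ending in 4-methylpiperazin-1-yl.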